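This account rests on a few compounds, and the source may have more. Where it says the series, first, only, none or still open, it means among the compounds named here.

Series readings in an ADME assay on Caco-2 cells (Homo sapiens) for inhibition, read by MTT assay, with a stated time of 72 h; on this read-out lower numbers stand for stronger inhibition and higher numbers for weaker inhibition:

- Compound 1 `C=CCNC(=C\C(=O)/C=C/c1ccc(O)c(OC)c1)/C=C/c1ccc(O)c(OC)c1`: > 25000 nM
- Compound 2 `COc1cc(/C=C/C(=O)CC(=O)/C=C/c2ccc(OC(C)=O)c(OC)c2)ccc1OC(C)=O`: > 25000 nM
- Compound 3 `O=C(/C=C(/C=C/c1ccc(O)cc1)NC1CCCCC1)/C=C/c1ccc(O)cc1`: > 25000 nM

Each of these readings is a limit of the assay and not a number. The position of compound 1 is therefore only partly defined, and the same holds for the series as a whole, which so far gives (the limit of > 25000 nM in this assay, at which 3 of the 3 values shown sit). For the measured compounds named here, no compound can be ranked against another on these readings, and no measured step is available to size a structural change.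

Compound 4 `CCCCNC(=C\C(=O)/C=C/c1ccc(O)c(OC)c1)/C=C/c1ccc(O)c(OC)c1` keeps the core of compound 1 and alters only the chain on the amine nitrogen, allylamino to butylamino. The change is propyl in place of vinyl on a saturated chain carbon bound to an amine nitrogen.

In this assay, no step beyond the scatter is expected in either direction. This expectation rests on compound 1 and its limit of > 25000 nM. The expected change is a number no higher from compound 1 to compound 4 (the limit leaves the size open). A report of the limit alone is the most likely outcome. For compound 4 the estimated value is 25000 nM, with an expected range of 12000 nM to 50000 nM.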

Compound 4, half-maximal inhibitory concentration: > 25000 nM
Compound 4: a limit, no number (the forecaster's own chance of this, stated with the estimate: 85%); the middle value lies on the limit itself.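

For the compounds shown here, compound 1 and compound 4 both read as limits in this assay, and no step between them can be read. The series gives a single reading: the limit of > 25000 nM in this assay, at which 4 of the 4 values shown sit.

The compounds shown leave open whether the chain on the amine nitrogen changes the inhibition at all, and how strong the inhibition of any of these compounds is.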